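The source may report more compounds than this note shows. Statements on the series, on what has been measured and on what is new or still open speak of the compounds shown alone.

Measured in a functional assay on A549 cells (Homo sapiens) for antiproliferative activity, read by MTT assay, with a stated time of 24 h; on this read-out higher numbers stand for weaker inhibition and lower numbers for stronger inhibition:
- Compound 1 `O=C(NNc1cccc(Cl)c1)c1ccc(NS(=O)(=O)c2cnc(O)nc2O)cc1`: 7290 nM
- Compound 2 `Cc1ccccc1NNC(=O)c1ccccc1NS(=O)(=O)c1cnc(O)nc1O`: > 20000 nM

In this assay, among the compounds with values here, compound 1 gives 7290 nM, the only actual number available. Compound 2 stands at > 20000 nM, which is a limit of the assay and not a number. Compound 3 `O=C(NNC(=O)c1ccccc1Cl)c1ccc(NS(=O)(=O)c2cnc(O)nc2O)cc1` keeps the core of compound 1 but carries (2-chlorophenyl)carbonyl in place of 3-chlorophenyl on an amine nitrogen. Within the data shown here, no measured step speaks directly to this change, so the expectation is tentative. The expected step of a 1.4-fold higher number from compound 1 to compound 3 (0.14 log units; within the scatter) is a small weakening, barely beyond the scatter. For compound 3 the estimated value is 10000 nM, with an expected range of 3500 nM to 30000 nM.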

Compound 3, half-maximal inhibitory concentration: 1900 nM
The estimate for compound 3 lay 5.3-fold (0.72 log units) above the measured number; measured number below the stated range.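

In this assay, within the data shown here, putting (2-chlorophenyl)carbonyl in place of 3-chlorophenyl on an amine nitrogen gives a 3.8-fold lower number from compound 1 to compound 3 (0.58 log units; beyond the scatter), the first measured evidence that this position can take a change that strengthens inhibition. The step combines a new carbonyl with a shift in the chlorine's numbered position, so neither can be credited alone. Nothing measured here explains the step.

Going by these compounds, it remains open how (3-chlorophenyl)carbonyl would compare with compound 3. An unsubstituted benzoyl group or a smaller acetyl group at this position is equally unresolved.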